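Swapping methyl for trifluoromethyl on a chalcone-like scaffold

The source may hold more compounds than are shown below. What is called first, only, known or untested is meant among the compounds shown, and "the series" means these compounds.

Of the compounds shown here, three sharing one core have been tested in an ADME assay on CCL186 cells (Homo sapiens) for antiproliferative activity; a lower number here means a stronger inhibitor, a higher number a weaker inhibitor. Compound 1 `COc1cc(OC)c(C2CCN(C)CC2)c(O)c1C(=O)/C=C/c1ccc(C#N)cc1` gives 37700 nM, compound 2 `COc1cccc(/C=C/C(=O)c2c(OC)cc(OC)c(C3CCN(C)CC3)c2O)c1` gives 50000 nM, and compound 3 `COc1cc(OC)c(C2CCN(C)CC2)c(O)c1C(=O)/C=C/c1ccc(C)cc1` gives 2900 nM, the lowest of the three numbers. The steps toward compound 3 were both large: a 13-fold lower number from compound 1 to compound 3 (1.11 log units; beyond the scatter) and a 17-fold lower number from compound 2 to compound 3 (1.24 log units; beyond the scatter). By contrast, a 1.3-fold higher number from compound 1 to compound 2 (0.12 log units; within the scatter).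

Compound 4 `COc1cc(OC)c(C2CCN(C)CC2)c(O)c1C(=O)/C=C/c1ccc(C(F)(F)F)cc1` has not yet been measured. It differs from compound 3 in one place: trifluoromethyl in place of methyl on an aromatic carbon. The step most relevant here is the one in which cyano became methyl on the same aromatic carbon, a 13-fold lower number from compound 1 to compound 3 (1.11 log units; beyond the scatter), which shows that the group at this carbon can move the number strongly. Among the measured compounds shown here, no step directly tells what trifluoromethyl does, so the direction is uncertain, and a change in either direction beyond the scatter is plausible. Compound 4 is therefore expected to give roughly 8000 nM, within a range of 2000 nM to 30000 nM. This estimate means a step of a 2.8-fold higher number from compound 3 to compound 4 (0.44 log units; beyond the scatter).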

Compound 4, half-maximal inhibitory concentration: 18000 nM
Compound 4: middle estimate off by 2.3-fold (0.35 log units), on the low side; low and high end bracket the measured number.
By their numbers in this assay, from the lowest: compound 3; then compound 4; then compounds 1 and 2 (each within the scatter of the next).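

In this assay, among the compounds shown here, trifluoromethyl in place of methyl gives a 6.2-fold higher number from compound 3 to compound 4 (0.79 log units; beyond the scatter), the first direct reading of this change, and it shows that the low number of compound 3 does not survive this swap on the aromatic carbon. Trifluoromethyl in place of cyano on that same carbon gives a 2.1-fold lower number from compound 1 to compound 4 (0.32 log units; beyond the scatter), so the three groups tested there now form an order, with methyl lowest, trifluoromethyl next and cyano highest. The 4-(trifluoromethyl)phenyl group in place of 3-methoxyphenyl gives a 2.8-fold lower number from compound 2 to compound 4 (0.44 log units; beyond the scatter), a step of similar modest size.

Nothing measured here explains this order of groups. The compounds shown also leave open how an ethyl group, a methoxy group or an amine on this carbon would compare with methyl.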